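Piperazinyl in Place of Aminoethylamino on a Limit-Bound Series

The source may hold more compounds than are shown below. What is called first, only, known or untested is meant among the compounds shown, and "the series" means these compounds.

Compound 1 is `NCCCNc1c(C(=O)NCc2ccc(F)cc2)ncc2cccnc12`; in a functional assay on HCT-116 cells (Homo sapiens) for cytotoxicity, read by MTT assay, with a stated time of 72 h (on this read-out lower numbers stand for stronger inhibition and higher numbers for weaker inhibition), compound 1 gives > 10000 nM, which is a limit of the assay. Compound 2 is `NCCNc1c(C(=O)NCc2ccc(F)cc2)nc(Br)c2cccnc12`; here compound 2 gives > 20000 nM, again a limit. Compound 3 is `O=C(NCCCNc1c(C(=O)NCc2ccc(F)cc2)nc(Br)c2cccnc12)c1ccccc1`; compound 3 gives > 10000 nM, also a limit.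

Compound 2 therefore stands only at a limit, and the two further values shown are likewise limits: two of the three values sit at the limit of > 10000 nM in this assay, at which 2 of the 3 values shown sit, one at the limit of > 20000 nM in this assay, at which 1 of the 3 values shown sits. Among the compounds with values here, the single step among measured compounds that differs in one place, a step that the two limits leave unreadable from compound 2 to compound 3, is left unreadable by the two limits, so no measured step of readable size bears on the change that leads to compound 4.

Compound 4 is `O=C(NCc1ccc(F)cc1)c1nc(Br)c2cccnc2c1N1CCNCC1`. It differs from compound 2 by piperazin-1-yl in place of (2-aminoethyl)amino on an aromatic carbon.

With no readable step to lean on, the account expects no change beyond the scatter, and it expects compound 4 most likely to remain at a limit as well. For compound 4 the estimate is 20000 nM, within 5000 nM to 60000 nM. The step this estimate means is a number no higher from compound 2 to compound 4 (the limit leaves the size open), expected to be unreadable in the same way.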

Compound 4, half-maximal inhibitory concentration: > 10000 nM
Compound 4 ended at the assay's limit; the forecaster's own chance of this, stated with the estimate: 70%; the middle value lies beyond the limit too.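

In this assay compound 4 gives > 10000 nM, which is a limit of the assay. Within the data shown here, compound 2 also stands at a limit, so no step between compound 2 and compound 4 can be read. The compounds shown leave open how piperazin-1-yl and (2-aminoethyl)amino compare on this read-out, since none of them has a value inside the assay's range.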